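Hydroxy to Chloro: An Expectation for Compound 4

The source may hold more compounds than are shown below. What is called first, only, known or untested is meant among the compounds shown, and "the series" means these compounds.

Compound 1, `Oc1cc(-c2ccccc2)nc2c(O)cccc12`: in a functional assay on L1210 (1565) cells (Mus musculus) for cytotoxicity (a lower number here means that less compound is needed, a higher number that more compound is needed for the effect), compound 1 reaches only a limit, > 10 ug/mL.
Compound 2, `Oc1ccc2nc(-c3ccccc3)cc(O)c2c1`: in this assay compound 2 gives 0.83 ug/mL.
Compound 3, `CC(C)COc1cc(-c2ccccc2)nc2ccccc12`: in this assay compound 3 reaches only a limit, > 10 ug/mL.

Among the compounds with values here, compound 2 stands alone among the three as the one with a measured number; the other two sit at the limit of > 10 ug/mL in this assay, at which 2 of the 3 values shown sit. Within the data shown here, no two measured compounds differ from each other in a single place, so the measured set gives no step whose size could be read off directly, and compound 1 and compound 3 each differ from compound 2 in more than one respect.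

Compound 4, `Oc1cc(-c2ccccc2)nc2ccc(Cl)cc12`, has not yet been tested. It differs from compound 2 in one place: chloro in place of hydroxy on an aromatic carbon.

Since nothing measured tells how this exchange plays out, the step in this assay can only be expected. A moderate step toward a higher number, somewhat beyond the usual scatter, is expected, that is a 3.6-fold higher number from compound 2 to compound 4 (0.56 log units; beyond the scatter). Compound 4 is accordingly estimated at 3 ug/mL, with a range from 0.7 ug/mL to 15 ug/mL, and a real chance remains that this assay again reports only a limit.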

Compound 4, half-maximal effective concentration: 0.5 ug/mL
Beside the measured number, compound 4's estimate is 6.0-fold (0.78 log units) above it; the measured number lies below the stated range.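

In this assay, within the data shown here, putting chloro in place of hydroxy on this aromatic carbon gives a 1.7-fold lower number from compound 2 to compound 4 (0.22 log units; within the scatter), the first step in the set that can be read directly, and the two compounds cannot be told apart. At this place, para to a fused ring, the measured number therefore does not depend on keeping hydroxy, with its hydrogen-bond donor and acceptor: chloro, which is counted with neither, gives a result within the scatter of it. Compound 4 also adds a second measured number to the set, and it does not join the compounds that reach only a limit: the limit of > 10 ug/mL in this assay, at which 2 of the 4 values shown sit.

On these data alone, whether this tolerance extends beyond chloro remains open, since a single exchange cannot show how an amine, a methoxy group or a carboxylic acid at the same carbon would behave in this assay. Among these compounds, compound 1 and compound 3 each differ from compound 2 and from compound 4 in more than one place, so no steps to them can be read, and what separates them from the two measured compounds stays unresolved.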